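The source may hold more compounds than are shown below. What is called first, only, known or untested is meant among the compounds shown, and "the series" means these compounds.

Measured so far:
compound 1 `c1cncc(N2CCN(Cc3nc4ccccc4[nH]3)CC2)c1`: 24.9% in a functional assay on HEK293 cells with D(4) dopamine receptor (Homo sapiens) as the target; a lower number here means a smaller maximal response, a higher number a larger maximal response
compound 2 `COc1cccc(N2CCN(Cc3nc4ccccc4[nH]3)CC2)c1`: 5% in this assay

Within the data shown here, compound 2 stands lowest of the two numbers in this assay; its nearest neighbour is compound 1, and the single measured step, a number 19.9 percentage points lower from compound 1 to compound 2 (beyond the scatter), runs downward. Compound 3 `COc1ccc(N2CCN(Cc3nc4ccccc4[nH]3)CC2)cc1` differs from compound 2 in one place: 4-methoxyphenyl in place of 3-methoxyphenyl on an amine nitrogen in a ring. Among the measured compounds shown here, no measured step exchanges one methoxyphenyl for another, so that step gives no direct guide; it shows only that a change of the group on the amine nitrogen in the ring can move the largest response by a modest amount. Since compound 2 already gives 5%, little room remains downward, and the step expected in this assay is one within the scatter, or at most a small rise: a number 5 percentage points higher from compound 2 to compound 3 (within the scatter). Compound 3 is accordingly estimated at 10%, with a range from 0% to 30%.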

Compound 3, largest response reached (reported as efficacy), in percent of the reference or control that the assay uses: 4.8%
Compound 3: the middle estimate sits 5.2 percentage points above what was measured; low and high end bracket the measured number.
By their numbers in this assay, from the lowest: compounds 3 and 2 (each within the scatter of the next); then compound 1.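

Exchanging 3-methoxyphenyl for 4-methoxyphenyl on the amine nitrogen in the ring (a number 0.2 percentage points lower from compound 2 to compound 3 (within the scatter)) leaves the two compounds indistinguishable in this assay, so at this position the two methoxyphenyl groups cannot be told apart by their largest response. The step from pyridin-3-yl to 4-methoxyphenyl (a number 20.1 percentage points lower from compound 1 to compound 3 (beyond the scatter)) matches the earlier step to 3-methoxyphenyl (a number 19.9 percentage points lower from compound 1 to compound 2 (beyond the scatter)), and among these three compounds, compound 1 alone stands apart from the other two. Nothing available explains why the two methoxyphenyl groups match or why pyridin-3-yl differs from them.

Going by these compounds, it remains open whether the higher response of compound 1 is specific to pyridin-3-yl or would also appear with pyridin-4-yl. An unsubstituted phenyl or a 3-hydroxyphenyl on the same nitrogen would show whether the methoxy group matters to the response in this assay at all.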